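One Chlorine Removed, Twice, in a Lipophilicity Assay

A few compounds are considered here, and "the series" means these few. Any claim that something is new, unique, unknown or untested is made for them only; others in the source may bear on it.

Three compounds have been measured in a physicochemical assay for lipophilicity; a higher number here means a more lipophilic compound, a lower number a more polar compound:
compound 1, `O=C1/C(=C/c2ccc(Cl)cc2)CCC/C1=C\c1ccc([N+](=O)[O-])cc1`, gives 5.08
compound 2, `O=C1/C(=C/c2ccc(Cl)cc2)CCC/C1=C\c1ccccc1[N+](=O)[O-]`, gives 4.86
compound 3, `O=C1/C(=C/c2ccccc2)CCC/C1=C\c1ccc([N+](=O)[O-])cc1`, gives 5.08

Compound 1 and compound 3 differ by hydrogen in place of chloro on an aromatic carbon, and the step in this assay is no change at the digits printed from compound 1 to compound 3 (within the scatter). Compound 2 has the same atoms as compound 1 joined differently; the difference between the two cores is not broken down here. Its value sits within the scatter of both compound 1 and compound 3, so no order among the three can be read.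

Compound 4, `O=C1/C(=C/c2ccccc2)CCC/C1=C\c1ccccc1[N+](=O)[O-]`, is not yet measured. It differs from compound 2 by hydrogen in place of chloro on an aromatic carbon, the same change as from compound 1 to compound 3, at the same kind of place. Because no change at the digits printed from compound 1 to compound 3 (within the scatter) showed no movement, the step of no change at the digits printed from compound 2 to compound 4 (within the scatter) is expected to be of the same size. Compound 4 is therefore estimated at 4.86, between 4.5 and 5.2.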

Compound 4, partition coefficient: 4.86
Compound 4: middle estimate and measured number agree at the digits printed; the measured number falls inside the stated range.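

In this assay hydrogen in place of chloro on an aromatic carbon gives no change at the digits printed from compound 2 to compound 4 (within the scatter) and, on the other core, no change at the digits printed from compound 1 to compound 3 (within the scatter) so the change leaves the number in place on both cores shown. This is a single pair on each of two cores: it shows that the absence of a step carried across, but not that a step of real size would carry, nor that any further core would behave alike. No measurement shown here explains why the number stays in place.

The compounds shown leave open whether the same replacement would give no step on a third core. They also leave open whether hydrogen in place of an amine or a carboxylic acid on that aromatic carbon would do the same.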